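Naphthalen-2-yl for 4-(trifluoromethyl)phenyl on a shared core

The source may hold more compounds than are shown below. What is called first, only, known or untested is meant among the compounds shown, and "the series" means these compounds.

Readings so far in a functional assay on HEL cells (Homo sapiens) for cytotoxicity; a higher number here means that more compound is tolerated, a lower number that less compound is tolerated
compound 1 `CO[C@@H]1[C@@H](OC)[C@H](c2ccccc2)O[C@@H]2CO[C@@H](c3ccc(C)cc3)O[C@@H]12` gives "not determined" (no result reported)
compound 2 `CO[C@@H]1[C@@H](OC)[C@H](c2ccccc2)O[C@@H]2CO[C@@H](c3cccc(Cl)c3)O[C@@H]12` gives "not determined" (no result reported)
compound 3 `CO[C@@H]1[C@@H](OC)[C@H](c2ccccc2)O[C@@H]2CO[C@@H](c3ccc(C(F)(F)F)cc3)O[C@@H]12` gives > 50 ug/mL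

Compound 1 and compound 2 have no reported result, so the series offers a single reading. For compound 3 the result (> 50 ug/mL) is a limit of the assay and not a number. Among the compounds with values here, with no step between measured compounds, this assay gives no direct guide to how much a change on this core matters.

The next compound is compound 4 `CO[C@@H]1[C@@H](OC)[C@H](c2ccccc2)O[C@@H]2CO[C@@H](c3ccc4ccccc4c3)O[C@@H]12`, which carries naphthalen-2-yl in place of 4-(trifluoromethyl)phenyl on a saturated ring carbon. The rest of the structure stays the same.

The expectation rests on compound 3 alone, whose reading of > 50 ug/mL is again a limit. The expected change is a number no higher from compound 3 to compound 4 (the limit leaves the size open), and no shift beyond the usual scatter is anticipated in either direction. For compound 4 the estimated value is 50 ug/mL, with an expected range from 20 ug/mL to 100 ug/mL, and the assay may well report only a limit again.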

Compound 4, half-maximal cytotoxic concentration: > 50 ug/mL
Compound 4: a limit, no number; the forecaster's own chance of this, stated with the estimate: 75%; the middle value sits exactly at the limit.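

In this assay, within the data shown here, compound 3 and compound 4 both give only a limit and not a number, so no step between them can be read: the limit of > 50 ug/mL in this assay, at which 2 of the 4 values shown sit. The compounds shown leave open whether swapping 4-(trifluoromethyl)phenyl for naphthalen-2-yl changes the tolerated concentration at all.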